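Swapping the amine side chain on the amide-linked benzamide

This account rests on a few compounds, and the source may have more. Where it says the series, first, only, none or still open, it means among the compounds named here.

Of the compounds shown here, three share a sulfamate-bearing core and have been tested in an assay on HEK293 cells for inhibition of Steryl-sulfatase (Homo sapiens), tested at 0.1 uM; on this read-out higher numbers stand for a stronger effect at the one concentration tested and lower numbers for a weaker effect. Compound 1 `CCN(Cc1ccccc1)Cc1ccc(CN2CCc3ccc(OS(N)(=O)=O)cc3C2)cc1` carries a benzylic link and gives 1%. Compound 2 `CCN(Cc1ccc(Br)cc1)c1cccc(C(=O)N2CCc3ccc(OS(N)(=O)=O)cc3C2)c1` joins the core through an amide and gives 24.2%. Compound 3 `CCN(Cc1ccc(F)cc1)c1cccc(C(=O)N2CCc3ccc(OS(N)(=O)=O)cc3C2)c1` gives 10.9%. Among the compounds with values here, the only single-point step measured is a number 13.3 percentage points lower from compound 2 to compound 3 (beyond the scatter). Compound 3 therefore sits below compound 2 by a step beyond the scatter, while its value and that of compound 1 lie within the scatter of each other, so those two cannot be told apart on this read-out.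

Compound 4 `CN(CCCN1CCCCC1)c1cccc(C(=O)N2CCc3ccc(OS(N)(=O)=O)cc3C2)c1` differs from compound 3 in one place: methyl(3-(piperidin-1-yl)propyl)amino in place of ethyl(4-fluorobenzyl)amino on an aromatic carbon. Within the data shown here, no measured step bears directly on this change; the fluoro-for-bromo step from compound 2 to compound 3 concerns a halogen on the benzyl ring that is no longer present, and compound 1 differs in the linker as well. The change is a full exchange of the substituent, so a shift in either direction is possible, but nothing measured points to a large one. The step from compound 3 to compound 4 is expected to be a number 0.9 percentage points lower from compound 3 to compound 4 (within the scatter). Compound 4 is estimated at 10%, within 0% to 30%, because compound 3 gives 10.9% and the measured steps are modest.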

Compound 4, a percentage reported as inhibition, at one concentration (the size of the read-out at that concentration, not a potency): 24.1%
Compound 4: middle estimate off by 14.1 percentage points, on the low side; the range from low to high includes it.
By their numbers in this assay, from the lowest: compounds 1 and 3 (each within the scatter of the next); then compounds 4 and 2 (each within the scatter of the next).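

In this assay, methyl(3-(piperidin-1-yl)propyl)amino in place of ethyl(4-fluorobenzyl)amino gives a number 13.2 percentage points higher from compound 3 to compound 4 (beyond the scatter), so a six-membered aromatic ring of carbon only in this side chain is not needed for a reading at this level. The same exchange starting from (4-bromobenzyl)(ethyl)amino gives a number 0.1 percentage points lower from compound 2 to compound 4 (within the scatter), which means that two side chains with very different rings cannot be told apart on this read-out, and this position accepts a full change of substituent without a loss. Nothing available here explains why these two side chains give such similar numbers.

On these data alone, what remains open is whether the piperidine ring itself matters or only the propyl chain that carries it, and a morpholine or a plain dimethylamino group at the end of that chain would help separate the two. As far as these compounds go, it also remains open whether a longer or shorter chain between the two nitrogens would move the number, and whether the side chain of compound 4 would behave the same way on the benzylic link of compound 1.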